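Extending the acid chain: an estimate for compound 4

This account rests on a few compounds, and the source may have more. Where it says the series, first, only, none or still open, it means among the compounds named here.

Compound 1 `COC(=O)CNC1=CS(=O)(=O)O[C@@]12[C@@H](CO[Si](C)(C)C(C)(C)C)O[C@@H](n1cc(C)c(=O)n(C)c1=O)[C@@H]2O[Si](C)(C)C(C)(C)C`: 105000 nM
Compound 2 `Cc1cn([C@@H]2O[C@H](CO[Si](C)(C)C(C)(C)C)[C@@]3(OS(=O)(=O)C=C3NCC(=O)C(=O)O)[C@H]2O[Si](C)(C)C(C)(C)C)c(=O)n(C)c1=O`: 31100 nM
Compound 3 `COC(=O)C(=O)CNC1=CS(=O)(=O)O[C@@]12[C@@H](CO[Si](C)(C)C(C)(C)C)O[C@@H](n1cc(C)c(=O)n(C)c1=O)[C@@H]2O[Si](C)(C)C(C)(C)C`: 10300 nM

These numbers come from a functional assay on MT4 cells (Homo sapiens); a lower number here means that less compound is tolerated, a higher number that more compound is tolerated. Compound 1 gives the highest number of the three, so more of it is tolerated than of compound 2 or compound 3, and both gaps lie beyond the scatter. Compound 4 `Cc1cn([C@@H]2O[C@H](CO[Si](C)(C)C(C)(C)C)[C@@]3(OS(=O)(=O)C=C3NCCC(=O)O)[C@H]2O[Si](C)(C)C(C)(C)C)c(=O)n(C)c1=O` has not been measured. Compared with compound 1 the change is carboxymethyl in place of methoxycarbonyl on a saturated chain carbon bound to an amine nitrogen. Going by the values given here, two measured steps bear on this. a 10-fold lower number from compound 1 to compound 3 (1.01 log units; beyond the scatter). a 3.4-fold lower number from compound 1 to compound 2 (0.53 log units; beyond the scatter). Compound 4, like compound 2, carries a free acid, so the second step is the closer guide. A modest drop in this assay is therefore expected for compound 4, a 3.0-fold lower number from compound 1 to compound 4 (0.48 log units; beyond the scatter). The estimate for compound 4 is 35000 nM, with a range from 12000 nM to 100000 nM.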

Compound 4, half-maximal cytotoxic concentration: 11500 nM
For compound 4 the middle estimate is 3.0-fold (0.48 log units) above the measured one; measured number outside the range, below it.
By their numbers in this assay, from the lowest: compounds 3 and 4 (each within the scatter of the next); then compound 2; then compound 1.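

In this assay, the change to a 2-carboxyethyl chain gives a 9.1-fold lower number from compound 1 to compound 4 (0.96 log units; beyond the scatter), so this position responds strongly to a change that keeps the same atoms. Two chains ending in a free acid are not interchangeable here, since carboxymethyl in place of carboxycarbonyl gives a 2.7-fold lower number from compound 2 to compound 4 (0.43 log units; beyond the scatter). The free acid and the keto ester reach similar numbers, with a 1.1-fold higher number from compound 3 to compound 4 (0.05 log units; within the scatter). The compounds shown leave open how an amide, an amine or a longer chain on this saturated chain carbon would behave. Nothing measured here accounts for these shifts.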